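Replacing 2,3-difluorophenyl with 4-hydroxyphenyl near the assay limit

A few compounds are considered here, and "the series" means these few. Any claim that something is new, unique, unknown or untested is made for them only; others in the source may bear on it.

Compound 3 (`O=C(Nc1ccc(F)c(-c2nc3ncc(-c4cccc(F)c4F)cc3[nH]2)c1)N1CCCC1`) gives > 50000 nM in an ADME assay on HepG2 cells (Homo sapiens) for cytotoxicity, read by resazurin assay, with a stated time of 48 h (a higher number here means that more compound is needed for the effect, a lower number that less compound is needed), and this is a limit, not a number. Compound 2 (`O=C(Nc1ccc(F)c(-c2nc3ncc(-c4cncc(F)c4)cc3[nH]2)c1)N1CCCC1`) gives > 50000 nM in this assay and this too is a limit. Going by the values given here, compound 1 (`O=C(Nc1ccc(F)c(-c2nc3ncc(-c4ccc(F)cc4F)cc3[nH]2)c1)N1CCCC1`) gives 32400 nM as the one true number of the three. Compound 3 therefore has no exact place in the series and stands with the others at the limit of > 50000 nM in this assay, at which 2 of the 3 values shown sit, here.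

The next compound is compound 4 (`O=C(Nc1ccc(F)c(-c2nc3ncc(-c4ccc(O)cc4)cc3[nH]2)c1)N1CCCC1`). The change is 4-hydroxyphenyl in place of 2,3-difluorophenyl on an aromatic carbon and so 4-hydroxyphenyl takes the place of 2,3-difluorophenyl on an aromatic carbon. Among the compounds with values here, no measured step makes this exact exchange, but three steps alter the same carbon. They are an at least 1.5-fold higher number from compound 1 to compound 3 (0.18 log units; that floor lies within the scatter) and an at least 1.5-fold higher number from compound 1 to compound 2 (0.18 log units; that floor lies within the scatter) and a step that the two limits leave unreadable from compound 2 to compound 3 in that order. The first two therefore show only a floor within the scatter, and the third gives no size at all. On that basis no step beyond the scatter is expected in this assay in either direction. The estimated change is an at least 1.2-fold lower number from compound 3 to compound 4 (0.09 log units; that floor lies within the scatter) and the result may again be only a limit. For compound 4 the expected value is 40000 nM with an estimated range from 16000 nM to 80000 nM in this assay.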

Compound 4, half-maximal effective concentration: > 50000 nM
Compound 4: no number, only a limit (the forecaster's own chance of this, stated with the estimate: 50%); at least 1.2-fold (0.09 log units) between middle value and limit.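

With 4-hydroxyphenyl, which brings a hydrogen-bond donor and a hydrogen-bond acceptor that 2,3-difluorophenyl lacks, this aromatic carbon still yields no exact number in this assay, so a ring carrying oxygen instead of fluorine now stands with the fluorinated rings of compound 2 and compound 3. Going by these compounds alone, the one readable comparison is an at least 1.5-fold higher number from compound 1 to compound 4 (0.18 log units; that floor lies within the scatter), which sets compound 4 no clearly apart from compound 1, while the steps from compound 2 and from compound 3 to compound 4 cannot be read, since both ends of each are limits. Compound 1, with 2,4-difluorophenyl, remains the only compound with a true number, and the series gathers at a single point: the limit of > 50000 nM in this assay, at which 3 of the 4 values shown sit.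

From the compounds shown here alone, how far compound 2, compound 3 and compound 4 lie beyond that limit stays open, and so does whether any of them truly differs from compound 1 or from the others. Also open, going by these compounds, is how an amine or a carboxylic acid in place of the hydroxyl on this phenyl ring would read in this assay.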